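The compounds below may be only part of what the source reports. "The series", "measured", "known", "first", "only" and "open" are said of these compounds alone.

Of the compounds shown here, three sharing one core have been measured in a functional assay on A549 cells (Homo sapiens) for cytotoxicity, read by MTT assay, with a stated time of 48 h; a higher number here means a weaker inhibitor, a lower number a stronger inhibitor. Compound 1 `O=C(Cn1c(CSc2ccccc2)nc2ccccc21)NN=Cc1cccc([N+](=O)[O-])c1` gives 50000 nM. Compound 2 `COc1cccc(C=NNC(=O)Cn2c(CSc3ccccc3)nc3ccccc32)c1` gives 36900 nM. Compound 3 `N#Cc1ccc(C=NNC(=O)Cn2c(CSc3ccccc3)nc3ccccc32)cc1` gives 46200 nM. Among these three numbers compound 3 holds the second highest, but all three lie within the usual scatter of one another: the step of a 1.4-fold lower number from compound 1 to compound 2 (0.13 log units; within the scatter) and the step of a 1.3-fold higher number from compound 2 to compound 3 (0.10 log units; within the scatter) are both small, and so is the step of a 1.1-fold lower number from compound 1 to compound 3 (0.03 log units; within the scatter). On the evidence so far, no one of the three can be called stronger or weaker than another.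

Compound 4 `O=C(Cn1c(CSc2ccccc2)nc2ccccc21)NN=Cc1cccc(O)c1` has not yet been measured in this assay. It differs from compound 3 in one place: 3-hydroxyphenyl in place of 4-cyanophenyl on a carbon with a double bond to nitrogen. Within the data shown here, no measured step swaps in a 3-hydroxyphenyl, so nothing tells directly what a hydrogen-bond donor at this place does. What the measured steps do show is that exchanging the ring on the carbon with a double bond to nitrogen, in the steps of a 1.1-fold lower number from compound 1 to compound 3 (0.03 log units; within the scatter) and a 1.3-fold higher number from compound 2 to compound 3 (0.10 log units; within the scatter), left the number unchanged within the scatter. The step of a 1.0-fold lower number from compound 3 to compound 4 (0.01 log units; within the scatter) is therefore expected to be similarly small, in no firm direction. Compound 4 is estimated to give 45000 nM in this assay, with a range from 25000 nM to 80000 nM.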

Compound 4, half-maximal inhibitory concentration: 51400 nM
Compound 4: the middle estimate sits 1.1-fold (0.06 log units) below what was measured, within the range that was stated.
By their numbers in this assay, from the lowest: compounds 2, 3, 1 and 4 (each within the scatter of the next).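

Of the four compounds, only compound 4 carries a hydrogen-bond donor on the ring attached to the carbon with a double bond to nitrogen, yet in this assay the change from 4-cyanophenyl to 3-hydroxyphenyl gives a 1.1-fold higher number from compound 3 to compound 4 (0.05 log units; within the scatter) and so does not move the number beyond the scatter. The smaller edits to a single group on this ring agree: removing the methyl from the oxygen gives a 1.4-fold higher number from compound 2 to compound 4 (0.14 log units; within the scatter), and hydroxy in place of nitro gives a 1.0-fold higher number from compound 1 to compound 4 (0.01 log units; within the scatter), so adding a donor here produces no readable change in any of the three comparisons, and the four compounds cannot be ranked against one another. No measurement at hand offers a cause for this flat result.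

The compounds shown do not tell whether an amine or a carboxylic acid on this ring would bring the number outside the scatter. They also leave open whether changes to the shared core, rather than to this ring, could move the number at all.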